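Swapping 3-chlorophenyl for 4-hydroxyphenyl on the amide

The source may report more compounds than this note shows. Statements on the series, on what has been measured and on what is new or still open speak of the compounds shown alone.

Measured so far in a functional assay on SiHa cells (Homo sapiens) for inhibition, read by CCK-8 assay, with a stated time of 72 h, tested at 10 uM; on this read-out higher numbers stand for more inhibition of growth at the one concentration tested and lower numbers for less inhibition of growth
- compound 1 `CN(C)C(=O)c1cc2cnc(Nc3ccc(NC(=O)C4(C(=O)Nc5cccc(Cl)c5)CC4)cc3)nc2n1C1CCCC1` gives 97.3%
- compound 2 `Nc1ccc(NC(=O)C2(C(=O)Nc3ccc(F)cc3)CC2)cc1F` gives 36%

Compound 1 holds the higher of the two numbers, and the gap down to compound 2 lies beyond the scatter. Among the measured compounds shown here, no measured pair differs in one place only, so no measured step guides the next change. Compound 3 `CN(C)C(=O)c1cc2cnc(Nc3ccc(NC(=O)C4(C(=O)Nc5ccc(O)cc5)CC4)cc3)nc2n1C1CCCC1` keeps the core of compound 1 and carries 4-hydroxyphenyl in place of 3-chlorophenyl on an amide-type nitrogen. A fall in this assay is expected rather than a rise, probably moderate but beyond the scatter, because compound 1 at 97.3% leaves little room upward. The expected change is a loss (a number 19.3 percentage points lower from compound 1 to compound 3 (beyond the scatter)). The estimate for compound 3 is 78% (expected range 45% to 97%).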

Compound 3, percent growth inhibition at one concentration: 94.3%
Compound 3: middle estimate off by 16.3 percentage points, on the low side, within the range that was stated.
By their numbers in this assay, from the lowest: compound 2; then compounds 3 and 1 (each within the scatter of the next).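

In this assay the exchange of 3-chlorophenyl for 4-hydroxyphenyl on the amide-type nitrogen gives a number 3 percentage points lower from compound 1 to compound 3 (within the scatter) and so leaves the number unchanged within the usual scatter. At this position on the core of compound 1, the chlorine-bearing ring can therefore give way to a ring with a hydrogen-bond donor and acceptor without a measurable change in growth inhibition at the one concentration tested. Nothing available explains this outcome or ties it to any property of either group.

From the compounds shown here alone, whether the position also holds its number with a carboxylic acid or an amine on the phenyl ring remains open. Also open, going by these compounds, is whether compound 1 and compound 3 would separate across a range of concentrations, which a single-concentration read-out cannot show.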